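From Dimethoxyphenyl to Bromophenyl on a Shared Amide

This account rests on a few compounds, and the source may have more. Where it says the series, first, only, none or still open, it means among the compounds named here.

Measured compounds:
compound 1 `COc1ccc(NC(=O)CN2CCN(c3nnc(Cc4ccncc4)c4ccccc34)CC2)cc1OC` — 26500 nM
compound 2 `COc1ccc(NC(=O)CN2CCN(c3nnc(Cc4ccccc4)c4ccccc34)CC2)cc1OC` — reported as not active, no number given

In a functional assay on A549 cells (Homo sapiens) for cytotoxicity, read by MTT assay, with a stated time of 72 h (a lower number here means a stronger inhibitor, a higher number a weaker inhibitor), compound 1 gives 26500 nM. In this assay compound 2 is reported as "not active" (no number reported), with no single number given. Compound 3 `O=C(CN1CCN(c2nnc(Cc3ccccc3)c3ccccc23)CC1)Nc1cccc(Br)c1` differs from compound 2 by 3-bromophenyl in place of 3,4-dimethoxyphenyl on an amide-type nitrogen. Within the data shown here, no measured pair shows this change, so the size of the step is unknown; given compound 2, a weak result is expected, with no shift beyond the scatter assumed. Compound 3 is expected at 40000 nM, ranging from 12000 nM to 150000 nM.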

Compound 3, half-maximal inhibitory concentration: "not active" (no number reported)
Compound 3: no number reported, and the estimate cannot be compared.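

Compound 2 and compound 3 are both reported as not active in this assay with no number, and no step can be read between them. No measurement shown here explains this result. Going by these compounds, how far 3-bromophenyl in place of 3,4-dimethoxyphenyl shifts the value stays open.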